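Swapping cyano for methylsulfamoyl at the limit of cytotoxicity

A few compounds are considered here, and "the series" means these few. Any claim that something is new, unique, unknown or untested is made for them only; others in the source may bear on it.

Measured so far in an ADME assay on H9c2 cells (Rattus norvegicus) for cytotoxicity; a higher number here means a weaker inhibitor, a lower number a stronger inhibitor (each value is a limit of the assay)
- Compound 1 `O=C(Nc1nc2ccc(Cl)cc2s1)C1CCC1` gives > 50000 nM as a limit
- Compound 2 `O=C(Nc1nc2cc(F)c(C(F)(F)F)cc2s1)C1CC1` gives > 50000 nM as a limit
- Compound 3 `N#Cc1cc2sc(NC(=O)C3CC3)nc2cc1F` gives > 50000 nM as a limit

Compound 3 stands at > 50000 nM as a limit of the assay and not as a number. Within the data shown here, the whole set shares one position, namely the limit of > 50000 nM in this assay, at which 3 of the 3 values shown sit, and no compound has yet given an actual number.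

Compound 4 `CNS(=O)(=O)c1cc2sc(NC(=O)C3CC3)nc2cc1F` keeps the core of compound 3 and changes one group. The change is methylsulfamoyl in place of cyano on an aromatic carbon and it puts methylsulfamoyl in place of cyano on an aromatic carbon, ortho to a fluoro group.

The closest measured change is a step that the two limits leave unreadable from compound 2 to compound 3 and so it offers no size to carry over. Among the measured compounds shown here, no measured step in this set replaces cyano, so the new group has no direct precedent here. The expectation therefore leans on compound 3, whose > 50000 nM is a limit and gives a starting point without a true number.

The step expected in this assay is a number no higher from compound 3 to compound 4 (the limit leaves the size open) and no change beyond the scatter is expected in either direction. The estimate for compound 4 is 50000 nM with an expected range from 25000 nM to 100000 nM and the assay will probably report only a limit again.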

Compound 4, half-maximal inhibitory concentration: > 50000 nM
Compound 4 gave a limit, no number; the forecaster's own chance of this, stated with the estimate: 85%; the middle value sits exactly at the limit.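

In this assay compound 4 gives > 50000 nM, a limit of the assay and not a number, so the steps to compound 4 from compound 2 and compound 3 cannot be read. The compounds shown leave open whether swapping these groups changes the read-out at all, as all of them share one position: the limit of > 50000 nM in this assay, at which 4 of the 4 values shown sit.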